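Tert-butyl for methoxy on two hydrazide cores

This account rests on a few compounds, and the source may have more. Where it says the series, first, only, none or still open, it means among the compounds named here.

Compound 1 `COc1ccc(C(=O)N/N=C/c2cc(I)c(O)c(I)c2)cc1` and compound 2 `CC(C)(C)c1ccc(C(=O)N/N=C/c2cc(I)c(O)c(I)c2)cc1` share one core, while compound 3 `COc1ccc(C(=O)NNC(=O)c2cc(I)cc(I)c2O)cc1` and compound 4 `CC(C)(C)c1ccc(C(=O)NNC(=O)c2cc(I)cc(I)c2O)cc1` share another; the difference between the two cores is not broken down here. In a functional assay on HepG2 cells (Homo sapiens) for cytotoxicity, with a stated time of 24 h (on this read-out lower numbers stand for stronger inhibition and higher numbers for weaker inhibition), compound 1 reaches only > 100000 nM, which is a limit of the assay and not a number. In this assay compound 2 gives 45900 nM. Compound 3 gives 132000 nM in this assay, the highest number of the two measured as numbers.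

The step of an at least 2.1-fold lower number from compound 1 to compound 2 (0.33 log units; beyond the scatter) is tert-butyl in place of methoxy on an aromatic carbon. Its true size is only bounded, because compound 1 sits at the limit of > 100000 nM in this assay, at which 1 of the 3 values shown sits.

The change from compound 3 to compound 4 is the same change, (tert-butyl in place of methoxy on an aromatic carbon), and its place is described in the same words. Among the compounds with values here, only the one measured step of an at least 2.1-fold lower number from compound 1 to compound 2 (0.33 log units; beyond the scatter) is available to carry it over, so the expectation is a step of at least that order, estimated as a 2.9-fold lower number from compound 3 to compound 4 (0.47 log units; beyond the scatter). Compound 4 is therefore expected to give about 45000 nM in this assay, most likely between 15000 nM and 130000 nM.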

Compound 4, half-maximal inhibitory concentration: 87300 nM
Compound 4: the middle estimate sits 1.9-fold (0.29 log units) below what was measured; the measured number falls inside the stated range.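

In this assay, tert-butyl in place of methoxy on the core of compound 3 gives a 1.5-fold lower number from compound 3 to compound 4 (0.18 log units; within the scatter) and so does not stand clear of the scatter on this core. The result therefore gives no firm support for carrying the change from one core to the other, nor does it show that the change fails to carry over, as this single step cannot settle either reading. Only two pairs bear on the question, and the comparison between them stays unresolved: the same change on two cores in this assay, an at least 2.1-fold lower number (0.33 log units; beyond the scatter) from compound 1 to compound 2 and a 1.5-fold lower number (0.18 log units; within the scatter) from compound 3 to compound 4; the limit leaves it open whether they differ

Still open, on these data alone, is the true size of the step on the core of compound 1, whose value is a limit and not a number. Also open, as far as these compounds go, is how an amine, a carboxylic acid or a longer chain at the same place on the aromatic ring would read on either core in this assay.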